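A few compounds are considered here, and "the series" means these few. Any claim that something is new, unique, unknown or untested is made for them only; others in the source may bear on it.

Measured in a functional assay on K562 cells (Homo sapiens) for antiproliferative activity, with a stated time of 72 h; a higher number here means a weaker inhibitor, a lower number a stronger inhibitor:
- Compound 1 `OC[C@H]1O[C@@H](n2cnc3c(NCc4ccc(F)cc4)ncnc32)[C@H](O)[C@@H]1O`: 2700 nM
- Compound 2 `Cc1cccc(CNc2ncnc3c2ncn3[C@@H]2O[C@H](CO)[C@@H](O)[C@H]2O)c1`: > 166000 nM

Compound 2 has no exact number, only a limit of the assay at > 166000 nM. Compound 3 `COc1cccc(CNc2ncnc3c2ncn3[C@@H]2O[C@H](CO)[C@@H](O)[C@H]2O)c1` differs from it by methoxy in place of methyl on an aromatic carbon. For the measured compounds named here, only one measured step bears on this change: an at least 61-fold higher number from compound 1 to compound 2 (1.78 log units; beyond the scatter). That large step shows that swapping a group on this aromatic ring can shift the result in this assay strongly. It involved different groups, however, so it gives only a loose guide. A small move toward a lower number is expected, an at least 1.8-fold lower number from compound 2 to compound 3 (0.26 log units; that floor lies within the scatter). Compound 3 is estimated at 90000 nM, with an expected range of 15000 nM to 250000 nM.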

Compound 3, half-maximal inhibitory concentration: > 166000 nM
Compound 3 gave a limit, no number; the forecaster's own chance of this, stated with the estimate: 55%; middle value at least 1.8-fold (0.26 log units) away from the limit.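

Replacing 4-fluorophenyl with 3-methoxyphenyl gives an at least 61-fold higher number from compound 1 to compound 3 (1.78 log units; beyond the scatter) in this assay. The large loss seen with 3-methylphenyl is therefore not unique to that group, since a second replacement at this position also ends far from compound 1. Compound 2 and compound 3 both give only a limit, so the step between methyl and methoxy cannot be read and the two groups cannot be ranked: the limit of > 166000 nM in this assay, at which 2 of the 3 values shown sit.

Still open, from the compounds shown here alone, is whether an amine or a carboxylic acid in place of methoxy would bring back a measurable value.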